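Triazole aryl swap on a spiro-fused scaffold

The source may report more compounds than this note shows. Statements on the series, on what has been measured and on what is new or still open speak of the compounds shown alone.

Measured so far:
Compound 1 `Cc1cccc(-n2nncc2CN2C(=O)C3(C(C#N)=C(N)Oc4c3c3nc5ccccc5nc3c3ccccc43)c3ccccc32)c1` in a functional assay on HCT-116 cells (Homo sapiens) for antiproliferative activity, read by MTT assay, with a stated time of 48 h; on this read-out higher numbers stand for weaker inhibition and lower numbers for stronger inhibition: > 50000 nM
Compound 2 `N#CC1=C(N)Oc2c(N)cc3nc4ccccc4nc3c2C12C(=O)N(Cc1cnnn1-c1ccccc1Br)c1ccccc12` in this assay: 12400 nM

In this assay, for the measured compounds named here, compound 2 gives 12400 nM, the only actual number in this small set. For compound 1 the assay reports only a limit, (the limit of > 50000 nM in this assay, at which 1 of the 2 values shown sits). Compound 3 `N#CC1=C(N)Oc2c(N)cc3nc4ccccc4nc3c2C12C(=O)N(Cc1cnnn1-c1c(Cl)cc(Cl)cc1Cl)c1ccccc12` differs from compound 2 by a single change: 2,4,6-trichlorophenyl in place of 2-bromophenyl on an aromatic nitrogen. Going by the values given here, no measured pair shows how such a change acts here, so the step of a 1.2-fold lower number from compound 2 to compound 3 (0.09 log units; within the scatter) is expected to stay within the usual scatter, with no clear direction. Compound 3 is therefore estimated at 10000 nM, with a range from 3000 nM to 40000 nM.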

Compound 3, half-maximal inhibitory concentration: 12100 nM
Compound 3: the middle estimate sits 1.2-fold (0.08 log units) below what was measured; the measured number falls inside the stated range.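

In this assay, for the compounds shown here, the first readable step at this position is a 1.0-fold lower number from compound 2 to compound 3 (0.01 log units; within the scatter), with 2,4,6-trichlorophenyl in place of 2-bromophenyl on an aromatic nitrogen. On this read-out, the two groups cannot be told apart. For compound 1, only a limit is reported: the limit of > 50000 nM in this assay, at which 1 of the 3 values shown sits.

On these data alone, it remains open how this assay would read with a benzyl group, a pyridine ring or a phenyl ring carrying a carboxylic acid on that nitrogen. The compounds shown also leave open whether any group there gives a number clearly apart from that of compound 2.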